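The compounds below may be only part of what the source reports. "The series", "measured", "known", "first", "only" and "open" are said of these compounds alone.

Measured so far:
compound 1, `O=C(Nc1cccnc1)c1cccnc1` — 3%
compound 2, `O=C(Nc1cccnc1)c1ccncc1` — 4%

In an assay on V79 cells for inhibition of cytochrome P450 11B1, mitochondrial (Homo sapiens), tested at 500 nM (on this read-out lower numbers stand for less inhibition and higher numbers for more inhibition at the one concentration tested (going by the name of the read-out)), compound 1 gives 3%. Its nearest neighbour on these numbers is compound 2, which in this assay gives 4%; the two values lie within the scatter of each other, so neither compound can be set apart from the other, and both sit close to no inhibition at all. Within the data shown here, no step between measured compounds is available here, so no measured change can be drawn on.

The unmeasured compound 3, `O=C(Nc1cccnc1)c1cncc(Br)c1`, differs from compound 1 by a single change: bromo in place of hydrogen on an aromatic carbon. Among the measured compounds shown here, with only two near-zero values known and no measured step to compare against, there is no basis in the numbers for expecting a large move; the step from compound 1 to compound 3 is expected to be small, possibly a modest rise, and may well stay within the scatter. On that footing compound 3 is expected to give about 10% in this assay, within a range from 0% to 35%. This would correspond to an expected step of a number 7 percentage points higher from compound 1 to compound 3 (within the scatter).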

Compound 3, a percentage reported as inhibition, at one concentration (the size of the read-out at that concentration, not a potency): 0.4%
The estimate for compound 3 lay 9.6 percentage points above the measured number, within the range that was stated.
By their numbers in this assay, from the lowest: compounds 3, 1 and 2 (each within the scatter of the next).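

In this assay, among these compounds, bromo in place of hydrogen on an aromatic carbon, two atoms from the ring nitrogen and meta to a group of 9 heavy atoms, comes out as a number 2.6 percentage points lower from compound 1 to compound 3 (within the scatter), the only step available, since compound 1 and compound 2 alone offered none. At this position, then, a single bromine atom does not take the read-out beyond the scatter around compound 1, and compound 3, at 0.4%, still sits close to no inhibition at the one concentration tested. No measurement at hand bears on why this change leaves the number where it is.

On these data alone, what remains open is whether a different group at this same position, such as an amine, a carboxylic acid or a longer chain, would move the number in this assay beyond the scatter, and whether bromo would do so at another place on the shared core. Since all three numbers lie near no inhibition, they also leave open whether any change to this core can bring a clear rise at this concentration.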